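Chloro for Fluoro on Two Cores in Prostate Cancer Cells

The source may report more compounds than this note shows. Statements on the series, on what has been measured and on what is new or still open speak of the compounds shown alone.

Compound 1, `O=C(COc1ccc(C(=O)/C=C/c2cccc(Cl)c2)cc1)N[C@H]1CCOC1=O`: 4990 nM
Compound 3, `O=C(COc1ccc(C(=O)/C=C/c2cccc(F)c2)cc1)N[C@H]1CCOC1=O`: 23200 nM
Compound 2, `O=C(CNc1ccc(F)cc1)N[C@H]1CCOC1=O`: > 64000 nM, a limit

The three were measured in a functional assay on PC-3 cells (Homo sapiens) for antiproliferative activity, read by MTT assay, with a stated time of 72 h; a lower number here means a stronger inhibitor, a higher number a weaker inhibitor. Compound 1 and compound 3 share one core, while compound 2 stands on another; the difference between the two cores is not broken down here. Compound 1 and compound 3 differ by chloro in place of fluoro on an aromatic carbon, and that step gave a 4.6-fold lower number from compound 3 to compound 1 (0.67 log units; beyond the scatter). For compound 2 only a limit is known, (the limit of > 64000 nM in this assay, at which 1 of the 3 values shown sits).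

Compound 4, `O=C(CNc1ccc(Cl)cc1)N[C@H]1CCOC1=O`, has not been measured. It differs from compound 2 by chloro in place of fluoro on an aromatic carbon, the same kind of change as between compound 3 and compound 1, though on the other core and with the place para rather than meta to a large group. The step from compound 2 to compound 4 is expected to be an at least 1.2-fold lower number from compound 2 to compound 4 (0.10 log units; that floor lies within the scatter), resting on the earlier step of a 4.6-fold lower number from compound 3 to compound 1 (0.67 log units; beyond the scatter) and on compound 2 showing only a limit, > 64000 nM. Compound 4 is therefore estimated at 50000 nM, between 15000 nM and 200000 nM.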

Compound 4, half-maximal inhibitory concentration: > 64000 nM
Compound 4: a limit, no number (the forecaster's own chance of this, stated with the estimate: 55%); middle value at least 1.2-fold (0.10 log units) from the limit.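

In this assay compound 4 gives > 64000 nM and this is a limit, not a number. Compound 2 also stands at a limit, so no step can be read between compound 2 and compound 4: the limit of > 64000 nM in this assay, at which 2 of the 4 values shown sit.

The compounds shown leave open whether chloro in place of fluoro shifts activity at all on the core of compound 2.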